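This account rests on a few compounds, and the source may have more. Where it says the series, first, only, none or still open, it means among the compounds named here.

Measured so far:
compound 1 `Cc1cc(C)c(NC(=O)N(Cc2ccc(-c3nnc(C)o3)cc2)C2CCCCCC2)c(C)c1` — > 0.32 mg/kg
compound 2 `Cc1cc(C)c(NC(=O)N(Cc2ccccc2)Cc2cccc(-c3cc[nH]n3)c2)c(C)c1` — > 1 mg/kg

In a functional assay on a cell-free system (plasma) with sterol O-acyltransferase, Soat (Rattus norvegicus) as the target (on this read-out higher numbers stand for an effect only at larger amounts of compound and lower numbers for an effect already at smaller amounts), compound 1 gives > 0.32 mg/kg, which is a limit of the assay and not a number. Compound 2 gives > 1 mg/kg in this assay, again a limit. Compound 1 therefore stands at the limit of > 0.32 mg/kg in this assay, at which 1 of the 2 values shown sits. Compound 2 stands at the limit of > 1 mg/kg in this assay, at which 1 of the 2 values shown sits. Among the measured compounds shown here, no step between measured compounds is available.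

Compound 3 `Cc1cc(C)c(NC(=O)N(Cc2ccc(-c3cnn(C)c3)cc2)C2CCCCCC2)c(C)c1` awaits measurement in this assay. It differs from compound 1 by 1-methyl-1H-pyrazol-4-yl in place of 5-methyl-1,3,4-oxadiazol-2-yl on an aromatic carbon. With only a limit for compound 1 as anchor, the expected step is a step that the limit leaves unreadable from compound 1 to compound 3, not beyond the scatter in either direction. Compound 3 is estimated at 0.5 mg/kg, in the range 0.15 mg/kg to 2 mg/kg, with a limit again quite possible.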

Compound 3, dose for half-maximal effect: 0.31 mg/kg
Compound 3: middle estimate off by 1.6-fold (0.21 log units), on the high side; the range from low to high includes it.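

In this assay, 1-methyl-1H-pyrazol-4-yl in place of 5-methyl-1,3,4-oxadiazol-2-yl on the aromatic carbon para to a large group gives an at least 1.0-fold lower number from compound 1 to compound 3 (0.01 log units; that floor lies within the scatter). Compound 3 is the first compound shown with a number instead of a limit, so this position can carry a readable result. The step remains only a floor because compound 1 stands at a limit: the limit of > 0.32 mg/kg in this assay, at which 1 of the 3 values shown sits.

From the compounds shown here alone, the true size of the step stays open. So does the response at this position to a simple amine or a carboxylic acid in place of the five-membered ring.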